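Aromatase series: nitro to phenyl on the phenoxy ring

The source may report more compounds than this note shows. Statements on the series, on what has been measured and on what is new or still open speak of the compounds shown alone.

Measured compounds:
compound 1 `N#Cc1ccc(C(c2ccc(C#N)cc2)n2cc(COc3ccccc3)nn2)cc1`, 11000 nM
compound 2 `N#Cc1ccc(C(c2ccc(C#N)cc2)n2cc(COc3ccc([N+](=O)[O-])cc3)nn2)cc1`, 7730 nM

In an assay on isolated protein for inhibition of Aromatase (Homo sapiens), read by fluorescence and colorimetric assay, with a stated time of 30 min (a higher number here means a weaker inhibitor, a lower number a stronger inhibitor), compound 2 gives 7730 nM, the lower of the two numbers; compound 1 sits nearby at 11000 nM, and the step of a 1.4-fold lower number from compound 1 to compound 2 (0.15 log units; within the scatter) is within the scatter. Compound 3 `N#Cc1ccc(C(c2ccc(C#N)cc2)n2cc(COc3ccc(-c4ccccc4)cc3)nn2)cc1` carries the change phenyl in place of nitro on an aromatic carbon. Within the data shown here, no measured step bears directly on this change; the only comparison shows that a substituent at this position leaves the number within the scatter. Compound 3 is therefore expected near compound 2, with a step of a 1.3-fold lower number from compound 2 to compound 3 (0.11 log units; within the scatter) that need not exceed the scatter. The estimate for compound 3 is 6000 nM, range 2500 nM to 15000 nM.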

Compound 3, half-maximal inhibitory concentration: 13400 nM
Compound 3: middle estimate off by 2.2-fold (0.35 log units), on the low side; measured number inside the range.
By their numbers in this assay, from the lowest: compounds 2, 1 and 3 (each within the scatter of the next).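

In this assay the larger change at this aromatic carbon, which brings in a second aromatic ring, gives a 1.7-fold higher number from compound 2 to compound 3 (0.24 log units; within the scatter) and, set against the unsubstituted ring, a 1.2-fold higher number from compound 1 to compound 3 (0.09 log units; within the scatter) as well. Hydrogen, nitro and phenyl thus all stand within the scatter of one another here, so even a group of 6 heavy atoms with no hydrogen-bond acceptors does not shift the number beyond it. No available evidence accounts for this flat reading. Still open, on these data alone, is whether an amine or a carboxylic acid at this carbon would shift the number beyond the scatter. The same question holds for a longer chain such as benzyloxy.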